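The compounds below may be only part of what the source reports. "The series", "measured", "known", "first", "only" and "open" are said of these compounds alone.

Compound 1 `CCOc1ccc2nc(Cl)c(/C=N/NC(=O)c3cc4ccc(O)cc4oc3=O)cc2c1` gives 19200 nM.
Compound 2 `O=C(N/N=C/c1cccnc1)c1cc2cc(Br)ccc2oc1=O` gives 19000 nM.
Compound 3 `CCOc1ccc(NC(=O)c2cc3ccc(O)cc3oc2=O)cc1` gives 17300 nM.

All three compounds were tested in a functional assay on HepG2 cells (Homo sapiens) for antiproliferative activity, read by fluorescence and resazurin assay, with a stated time of 48 h (a higher number here means a weaker inhibitor, a lower number a stronger inhibitor), which measures how strongly a compound holds back the growth of a human liver cancer cell line. On the numbers shown, compound 1 stands at the top of the three, but its gap to compound 2 and its gap to compound 3 both lie within the usual scatter of repeated measurements, so the three compounds cannot be told apart on this evidence.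

Compound 4 `CCOc1ccc2nc(Cl)c(/C=N/NC(=O)c3cc4ccccc4oc3=O)cc2c1` has not yet been measured. It differs from compound 1 in a single place: hydrogen in place of hydroxy on an aromatic carbon. The hydroxy leaves and a hydrogen enters on an aromatic carbon of the shared core. Among the compounds with values here, no pair of measured compounds isolates this change, so there is no direct guide to how far the number may move. In this assay the step is therefore expected to be small, in no particular direction, and most likely within the scatter. Compound 4 is estimated to give 20000 nM, with a range from 8000 nM to 50000 nM. This estimate implies a step of a 1.0-fold higher number from compound 1 to compound 4 (0.02 log units; within the scatter), essentially none beyond the scatter.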

Compound 4, half-maximal inhibitory concentration: 33100 nM
Estimate against measurement, compound 4: 1.7-fold (0.22 log units) below, and the stated range covers the measured number.
By their numbers in this assay, from the lowest: compounds 3, 2, 1 and 4 (each within the scatter of the next).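

In this assay, within the data shown here, the swap of hydroxy for hydrogen on an aromatic carbon of the shared core gives a 1.7-fold higher number from compound 1 to compound 4 (0.24 log units; within the scatter) and so offers the first direct view of this position, which the earlier compounds, differing in more than one place, could not give. Compound 1 and compound 4 cannot be told apart on this evidence, so the hydroxy is not shown to be needed for the activity seen in this cell assay, although a single pair cannot prove that it makes no difference. Nothing measured here bears on why the swap gave this result.

The compounds shown leave open whether a different group on this aromatic carbon, such as a methoxy, an amine or a fluorine, would move the number beyond the scatter. They also leave open whether the same swap of hydroxy for hydrogen would give a similar result on other compounds, including compound 3, which carries the hydroxy on the same kind of core but has a different group on its amide.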